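Compound 4: a stability estimate from three limits

A few compounds are considered here, and "the series" means these few. Any claim that something is new, unique, unknown or untested is made for them only; others in the source may bear on it.

- compound 1 `COc1ccc(-c2c(C)nc3c(N4CC[C@@H](NC(=O)Nc5ccccc5)C4)cc(C)nn23)cc1OC`: > 95%
- compound 2 `COc1ccc(-c2c(C)nc3c(N4CC[C@@H](NS(=O)(=O)c5ccccc5)C4)cc(C)nn23)cc1OC`: > 95%
- compound 3 `COc1ccc(-c2c(C)nc3c(N4CC[C@@H](NS(=O)(=O)c5ccc(Cl)cc5)C4)cc(C)nn23)cc1OC`: > 95%

These values all come from an ADME assay on microsomes from liver (Mus musculus) for metabolic stability, read by LC-MS, with NADPH named in the record, with a stated time of 60 min, tested at 1 uM, in the absence of a further agent; on this read-out lower numbers stand for a less stable compound and higher numbers for a more stable compound. In this test, compound 3 reads > 95%, which is a limit of the assay and not a number. The whole set offers only (the limit of > 95% in this assay, at which 3 of the 3 values shown sit).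

Compound 4 `COc1ccc(-c2c(C)nc3c(N4CC[C@@H](n5cc(-c6ccccc6)nn5)C4)cc(C)nn23)cc1OC` differs from compound 3 in one place: 4-phenyl-1H-1,2,3-triazol-1-yl in place of ((4-chlorophenyl)sulfonyl)amino on a saturated ring carbon. In words, 4-phenyl-1H-1,2,3-triazol-1-yl stands in place of ((4-chlorophenyl)sulfonyl)amino on a saturated ring carbon.

Among the compounds with values here, three measured steps bear on this change. Swapping the group on the amine nitrogen gives a step that the two limits leave unreadable from compound 1 to compound 2 and a step that the two limits leave unreadable from compound 1 to compound 3, while adding chloro gives a step that the two limits leave unreadable from compound 2 to compound 3. None of them has a readable size, and none removes that nitrogen or brings in a triazole, so they offer only a loose guide.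

Within the data shown here, with a step that the two limits leave unreadable from compound 1 to compound 3 as the closest precedent, the expected result is a number at least 2 percentage points lower from compound 3 to compound 4 (that floor lies within the scatter), a small downward move and none clearly beyond the scatter. For compound 4 the estimate is 93%, with an expected range from 72% to 100%.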

Compound 4, percent of the compound remaining: "unstable" (no number reported)
Nothing numeric was reported for compound 4, so the estimate cannot be set against anything.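

Within the data shown here, compound 4 is recorded in this assay only as "unstable" (no number reported), so no step from compound 3 to compound 4 can be read. The compounds shown leave open how large the difference in stability is when 4-phenyl-1H-1,2,3-triazol-1-yl stands in place of ((4-chlorophenyl)sulfonyl)amino.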